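A Bromo for Carboxy Swap on a Pyrazole-Amine Series

The source may report more compounds than this note shows. Statements on the series, on what has been measured and on what is new or still open speak of the compounds shown alone.

Three analogues built on a shared core have been examined in an assay for inhibition of Tryptophan 2,3-dioxygenase (Homo sapiens), with stated times of 10 min and 60 min, tested at 100 uM; a higher number here means a stronger effect of the compound at the concentration tested, a lower number a weaker effect. Compound 1, `O=C(O)c1cccc(CNc2cc(C(F)(F)F)cc3[nH]ncc23)c1`, gives 94% in this assay. Compound 2, `O=[N+](O)c1c(Cl)cccc1CNc1cc(C(F)(F)F)cc2[nH]ncc12`, gives 94%, so that compound 1 stands level with compound 2 at the digits shown. Compound 3, `O=[N+]([O-])c1cccc(CNc2cc(Br)cc3[nH]ncc23)c1`, gives 97%, and the gap from compound 1 to compound 3 lies within the usual scatter of such measurements. Within the data shown here, no pair of these three differs in only one place, so no single step can be read from them; all that can be said is that every one of the three reaches a high inhibition at the concentration tested.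

Compound 4, `FC(F)(F)c1cc(NCc2cccc(Br)c2)c2cn[nH]c2c1`, has not yet been measured. It differs from compound 1 as follows: bromo in place of carboxy on an aromatic carbon. Because compound 1 gives 94% and compound 3, which carries a bromo on its core, gives 97%, the expectation is that compound 4 will stay in the same high region, with a step from compound 1 to compound 4 of a number 2 percentage points lower from compound 1 to compound 4 (within the scatter), which is none beyond the scatter. The estimate for compound 4 is therefore 92%, with a range from 78% to 99%.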

Compound 4, a percentage reported as inhibition, at one concentration (the size of the read-out at that concentration, not a potency): 84%
Beside the measured number, compound 4's estimate is 8 percentage points above it, and the stated range covers the measured number.
By their numbers in this assay, from the lowest: compounds 4, 1, 2 and 3 (each within the scatter of the next, the first and the last beyond it).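

Among these compounds, replacing carboxy with bromo on this aromatic carbon, meta to a large group, gives a number 10 percentage points lower from compound 1 to compound 4 (within the scatter), and this is the first step that can be read directly, since no earlier pair differed in only one place. It shows that in this assay this position tolerates the loss of the carboxy, with its hydrogen-bond donor and acceptor, and the entry of a single bromine atom with neither, without a change beyond the usual scatter, so the carboxy of compound 1 is not needed here for a high reading at the concentration tested. No measurement is available that would explain this result.

Since the read-out is taken at a single concentration and the step lies within the scatter, the compounds shown leave open whether compound 1 and compound 4 would differ in potency. They also leave open whether an amine, a nitrile or a longer chain on the same aromatic carbon would keep the reading as high, or whether a bromo here would behave alike on a core that does not carry the trifluoromethyl group.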